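The source may hold more compounds than are shown below. What is called first, only, known or untested is meant among the compounds shown, and "the series" means these compounds.

Compound 1 `C[C@@H]1C(=O)O[C@H]2C[C@H](C)C(C(=O)O)=CC[C@@H]21` stands at the floor of what a functional assay on BV-2 cells (Mus musculus, strain C57BL6/J) for inhibition, read by Griess assay, with a stated time of 24 h (on this read-out higher numbers stand for weaker inhibition and lower numbers for stronger inhibition), can report: in this assay compound 1 gives > 10000 nM, which is a limit of the assay and not a number. Compound 2 `C[C@H]1C[C@@H]2OC(=O)[C@H](C)[C@H]2CC=C1C(=O)O` also gives only a limit, > 10000 nM. The step that the two limits leave unreadable from compound 1 to compound 2 is therefore unreadable because of the limit of > 10000 nM in this assay, at which 2 of the 3 values shown sit, even though the pair is a clean comparison because of the fact that compounds 1 and 2 differ only in the configuration as drawn. Going by the values given here, compound 3 `C=C1C(=O)O[C@H]2CC[C@H](C)C(/C=C/C(C)=O)=C[C@H]12` is the one member of the set with a number: in this assay compound 3 gives 1600 nM.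

Compound 4 `CC(=O)/C=C/C1=CC[C@H]2[C@H](C[C@@H]1C)OC(=O)[C@H]2C` departs from compound 1 by 2-acetylethenyl in place of carboxy on a double-bonded ring carbon. Among the compounds with values here, no measured step speaks directly to this change; the only measured step, from compound 1 to compound 2, gives no readable size. What the data do show is that compound 3, which bears the same 2-acetylethenyl group, returns a measurable value where the carboxy compounds return limits. On that basis compound 4 is expected to move off the limit toward stronger inhibition, a step of about an at least 5.0-fold lower number from compound 1 to compound 4 (0.69 log units; beyond the scatter). Compound 4 is estimated at 2000 nM, with a range of 700 nM to 6000 nM.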

Compound 4, half-maximal inhibitory concentration: > 10000 nM
Compound 4 was reported as a limit (the forecaster's own chance of this, stated with the estimate: 15%); middle value at least 5.0-fold (0.69 log units) away from the limit.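

Compound 4 also gives only a limit and not a number, so no new step can be read from it, because compounds 1 and 4 both sit at that limit: the limit of > 10000 nM in this assay, at which 3 of the 4 values shown sit.

The compounds shown leave open whether 2-acetylethenyl in place of carboxy changes inhibition at all, and in which direction.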